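Series notes: methyl on the chain carbon of compound 1

The source may report more compounds than this note shows. Statements on the series, on what has been measured and on what is new or still open speak of the compounds shown alone.

Among the measured compounds shown here, the three measured members all carry the same core and differ in the amino-acid-derived portion and in the chain that joins it to the terminal sulfonyl-substituted ring. Compound 1 `CC(C)=CCC/C(C)=C/CC/C(C)=C/CSc1ccccc1C(=O)NCC(=O)OC(C)CCOc1no[n+]([O-])c1S(=O)(=O)c1ccccc1` gives 11900 nM in a functional assay on SGC-7901 cells (Homo sapiens) for cytotoxicity, read by MTT assay, with a stated time of 48 h; on this read-out lower numbers stand for stronger inhibition and higher numbers for weaker inhibition. Compound 2 `CC(C)=CCC/C(C)=C/CC/C(C)=C/CSc1ccccc1C(=O)N[C@@H](C)C(=O)OCCOCCOc1no[n+]([O-])c1S(=O)(=O)c1ccccc1` gives 11300 nM, and compound 3 `CC(C)=CCC/C(C)=C/CC/C(C)=C/CSc1ccccc1C(=O)N1CCC[C@H]1C(=O)OCCOCCOc1no[n+]([O-])c1S(=O)(=O)c1ccccc1` gives 7860 nM. Compound 1 has the highest number of the three, but its gaps to compound 2 and to compound 3 both lie within the scatter, so no order among them can be read from these values.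

Compound 4 `CC(C)=CCC/C(C)=C/CC/C(C)=C/CSc1ccccc1C(=O)N[C@@H](C)C(=O)OC(C)CCOc1no[n+]([O-])c1S(=O)(=O)c1ccccc1` is the next member to be measured. It is related to compound 1 by a single change: methyl in place of hydrogen on a saturated chain carbon bound to an amide-type nitrogen and a carbonyl carbon. For the measured compounds named here, no measured pair isolates this change, so the size of its step is not known from the data. The closest hint is that the methyl-bearing chain carbon of compound 4 is also present, on a different linker, in compound 2, which gives 11300 nM, a number not separated from compound 1 beyond the scatter.

Compound 4 is therefore expected to give 11000 nM, within 5500 nM to 22000 nM. The step of a 1.1-fold lower number from compound 1 to compound 4 (0.03 log units; within the scatter) is expected to stay within the scatter, in no clear direction.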

Compound 4, half-maximal inhibitory concentration: > 50000 nM
Compound 4 was reported as a limit; the forecaster's own chance of this, stated with the estimate: 5%; at least 4.5-fold (0.65 log units) between middle value and limit.
By their numbers in this assay, from the lowest: compounds 3, 2 and 1 (each within the scatter of the next). At a limit, above all of these: compound 4.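

In this assay compound 4 gives > 50000 nM, and this value is a limit of the assay, not a number. Among the compounds shown here, the methyl in place of hydrogen, on a saturated chain carbon bound to an amide-type nitrogen and a carbonyl carbon, gives the first readable single-change step, an at least 4.2-fold higher number from compound 1 to compound 4 (0.62 log units; beyond the scatter), so with this linker the position does not tolerate the change without a shift in the read-out. The full size of the step stays unknown, since it is bounded on one side only: the limit of > 50000 nM in this assay, at which 1 of the 4 values shown sits.

The compounds shown do not tell whether an ethyl, isopropyl or benzyl group on this carbon would move the read-out in the same direction, or whether the opposite configuration of the methyl-bearing carbon would do the same. They also leave open whether the methyl has a comparable effect on the linker of compound 2, as no partner of compound 2 with hydrogen on this carbon is among them.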